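This account rests on a few compounds, and the source may have more. Where it says the series, first, only, none or still open, it means among the compounds named here.

Working notes on the phenylethynyl benzamide hydroxamates. Compound 1 `CC(C)C(NC(=O)c1ccc(C#Cc2ccccc2)cc1)C(=O)NO` sits at a limit of a physicochemical assay for lipophilicity; on this read-out higher numbers stand for higher lipophilicity and lower numbers for lower lipophilicity; its value, > 3, is a limit of the assay and not a number. Compound 2 `O=C(NC1(C(=O)NO)CCNCC1)c1ccc(C#Cc2ccccc2)cc1` gives 3 in this assay. Compound 3 `COCCNC(=O)C[C@H](NC(=O)c1ccc(C#Cc2ccccc2)cc1)C(=O)NO` gives 2 in this assay, the lowest of the two numbers read, with compound 2 one unit higher, a gap beyond the scatter. The step to compound 4 `C#CCNC(=O)C[C@H](NC(=O)c1ccc(C#Cc2ccccc2)cc1)C(=O)NO` is a single change: ethynyl in place of methoxymethyl on a saturated chain carbon bound to an amide-type nitrogen. Going by the values given here, no step between two measured compounds exists to measure this change against. A small rise in this assay is expected from compound 4, estimated at 2.4 with a range of 2 to 2.8, a step of a number 0.40 log units higher from compound 3 to compound 4 (beyond the scatter) that is expected to stay close to the scatter.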

Compound 4, distribution coefficient: 3
Compound 4: the middle estimate sits 0.60 log units below what was measured, outside the stated range (above it).
By their numbers in this assay, from the lowest: compound 3; then compounds 2 and 4 (each within the scatter of the next).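

On the (2-methoxyethyl)carbamoyl side chain, this assay now has its first single-change comparison: propargylcarbamoyl in its place gives a step of a number 1.00 log units higher from compound 3 to compound 4 (beyond the scatter). This position therefore responds measurably to ethynyl in place of methoxymethyl, though this rests on one pair. Compound 1 stands at a limit and not a number, which leaves little readable range in the assay: the limit of > 3 in this assay, at which 1 of the 4 values shown sits.

Still open, from the compounds shown here alone, is how a terminal amine or carboxylic acid on this chain would read. Going by these compounds, a longer chain ending in ethynyl also remains open, as does whether the step carries over to other side chains on the core.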